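Indazole to indole swap on the double-bonded ring carbon

This account rests on a few compounds, and the source may have more. Where it says the series, first, only, none or still open, it means among the compounds named here.

Compound 1 `NC(=O)c1ccc2c(c1)CCOC2CCN1CC=C(c2cccc3ccccc23)CC1` gives 224 nM in an assay on cell membranes from Cortex for binding affinity to Adrenergic receptor alpha-1 (Rattus norvegicus), read by radioligand binding; on this read-out lower numbers stand for stronger inhibition and higher numbers for weaker inhibition. Going by the values given here, compound 2 `NC(=O)c1ccc2c(c1)CCOC2CCN1CC=C(c2[nH]nc3cc(F)ccc23)CC1` gives 2.1 nM in this assay, and a 110-fold lower number from compound 1 to compound 2 (2.03 log units; beyond the scatter) is the only measured step so far. Among the compounds with values here, compound 2 thus stands lowest of the two numbers, with compound 1 as its sole neighbour. Compound 3 `NC(=O)c1ccc2c(c1)CCOC2CCN1CC=C(c2c[nH]c3ccc(F)cc23)CC1` carries 5-fluoro-1H-indol-3-yl in place of 6-fluoro-2H-indazol-3-yl on a double-bonded ring carbon; the six-membered carbon ring and the fluorine remain, the difference lies within the five-membered ring. Within the data shown here, the one step that bears on this position, a 110-fold lower number from compound 1 to compound 2 (2.03 log units; beyond the scatter), came with exchange of a carbon-only bicycle for a donor-bearing one, whereas compound 3 keeps a donor-bearing bicycle of the same size. A step in this assay within the scatter, or at most a modest rise of the number, is expected for compound 3, a 1.7-fold higher number from compound 2 to compound 3 (0.22 log units; within the scatter). Compound 3 is expected near 3.5 nM, within 1.2 nM to 12 nM.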

Compound 3, inhibition constant: 101 nM
Beside the measured number, compound 3's estimate is 29-fold (1.46 log units) below it; measured number above the stated range.
By their numbers in this assay, from the lowest: compound 2; then compound 3; then compound 1.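

In this assay the exchange at this position is far from neutral: the change gives a 48-fold higher number from compound 2 to compound 3 (1.68 log units; beyond the scatter) even though the entering 5-fluoro-1H-indol-3-yl keeps the 10 heavy atoms and 1 hydrogen-bond donor of the group it replaces, while going from 1 hydrogen-bond acceptor to 0 and from 2 ring nitrogens to 1. A donor-bearing bicycle of this size is thus not enough for a low number, since naphthalen-1-yl gives way to the indole with only a 2.2-fold lower number from compound 1 to compound 3 (0.35 log units; beyond the scatter) and most of the earlier gain stays with 6-fluoro-2H-indazol-3-yl. No available evidence accounts for this difference.

Open, on these data alone, is how the step divides between the ring nitrogen and the fluorine, whose number differs in the two group names; 6-fluoro-1H-indol-3-yl would separate them. Also open, as far as these compounds go, is what an unsubstituted 2H-indazol-3-yl would give.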